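Second chloro on the benzylidene of compound 2

The compounds below may be only part of what the source reports. "The series", "measured", "known", "first", "only" and "open" are said of these compounds alone.

Compound 2 `O=C1/C(=C/c2ccccc2Cl)Cc2ccccc21` gives 26500 nM in a functional assay on P388 cells (Mus musculus) for inhibition; a lower number here means a stronger inhibitor, a higher number a weaker inhibitor. Among the three measured compounds it stands second highest. Compound 3 `O=C1/C(=C/c2ccccc2F)Cc2ccccc21` gives 31700 nM in this assay, and the change from compound 2 to compound 3, fluoro in place of chloro on an aromatic carbon, gives a 1.2-fold higher number from compound 2 to compound 3 (0.08 log units; within the scatter). Going by the values given here, compound 1 `O=C1/C(=C/c2ccc(Cl)c(Cl)c2)CCCc2ccccc21`, on a different core and with a different chloro pattern, gives 12200 nM; no single step connects it to compound 2, so only the two values are compared, and compound 1 sits lower, beyond the scatter.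

Compound 4 `O=C1/C(=C/c2ccc(Cl)cc2Cl)Cc2ccccc21` differs from compound 2 by chloro in place of hydrogen on an aromatic carbon. Among the compounds with values here, no measured step shows the effect of adding a chloro on this core; the only step on the same core, from compound 2 to compound 3, is within the scatter. The expectation is therefore a small change in this assay, if any, with compound 1 hinting that a second chloro may lower the number. For compound 4 a value of 20000 nM is expected, between 8000 nM and 50000 nM, corresponding to an estimated step of a 1.3-fold lower number from compound 2 to compound 4 (0.12 log units; within the scatter).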

Compound 4, half-maximal inhibitory concentration: > 50000 nM
Compound 4 gave a limit, no number (the forecaster's own chance of this, stated with the estimate: 5%); middle value at least 2.5-fold (0.39 log units) from the limit.
By their numbers in this assay, from the lowest: compound 1; then compounds 2 and 3 (each within the scatter of the next). At a limit, above all of these: compound 4.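

Going by these compounds alone, this is the first step on the shared core that adds a group rather than exchanging one halogen for another: in this assay, chloro in place of hydrogen on an aromatic carbon, meta to a chloro group and para to a large group, gives an at least 1.8-fold higher number from compound 2 to compound 4 (0.27 log units; that floor lies within the scatter). The direction is upward, although the floor of this step does not by itself clear the scatter, so a real loss is suggested but not established. Compound 4 gives a limit and not a number, so the full size of the step cannot be read: the limit of > 50000 nM in this assay, at which 1 of the 4 values shown sits.

Open, from the compounds shown here alone, is whether an amine or a carboxylic acid at this place on the shared core would give a number rather than a limit. Also open, going by these compounds, is whether the same added chloro on the core of compound 1 would move the number in the same direction.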